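A Trifluoromethoxy Swap on the Sulfonyl Side

The compounds below may be only part of what the source reports. "The series", "measured", "known", "first", "only" and "open" are said of these compounds alone.

Three related compounds have been examined so far in a functional assay on DU-145 cells (Homo sapiens) for antiproliferative activity, read by fluorescence and propidium iodide staining, with a stated time of 96 h (a higher number here means a weaker inhibitor, a lower number a stronger inhibitor), and they share most of their structure. Compound 1 (`CC(O)(CS(=O)(=O)c1cc(C(F)(F)F)cc(C(F)(F)F)c1)C(=O)Nc1ccc(C#N)cc1C(F)(F)F`) gave no usable number and stands as "nd(insoluble)" (no result reported) with nothing to compare. Compound 2 (`CC(O)(CS(=O)(=O)c1cccc(C(F)(F)F)c1)C(=O)Nc1cc(C(F)(F)F)cc(C(F)(F)F)c1`) gives 11500 nM in this assay and compound 3 (`CC(O)(CS(=O)(=O)c1ccccc1C(F)(F)F)C(=O)Nc1cc(C(F)(F)F)cc(C(F)(F)F)c1`) gives 11000 nM on the same read-out. Among the measured compounds shown here, compound 3 therefore stands level with compound 2, the only other compound with a number.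

Compound 4 (`CC(O)(CS(=O)(=O)c1cccc(OC(F)(F)F)c1)C(=O)Nc1cc(C(F)(F)F)cc(C(F)(F)F)c1`) has not yet been measured. Compared with compound 3, it carries 3-(trifluoromethoxy)phenyl in place of 2-(trifluoromethyl)phenyl on a sulfonyl sulfur while the rest of the molecule stays the same.

For the measured compounds named here, no measured step makes this exact exchange, so the evidence is indirect. The closest guide is a 1.0-fold lower number from compound 2 to compound 3 (0.02 log units; within the scatter) for 2-(trifluoromethyl)phenyl in place of 3-(trifluoromethyl)phenyl on a sulfonyl sulfur. That step stays within the scatter, but it is a single pair and never tests the added oxygen.

The estimated step is no change at the digits printed from compound 3 to compound 4 (within the scatter) and so no shift beyond the scatter is expected in this assay for this change. Compound 4 is estimated at 11000 nM with 4500 nM to 27000 nM as the expected range of the measurement.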

Compound 4, half-maximal inhibitory concentration: 14100 nM
Estimate against measurement, compound 4: 1.3-fold (0.11 log units) below, within the range that was stated.
By their numbers in this assay, from the lowest: compounds 3, 2 and 4 (each within the scatter of the next).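

In this assay, among the compounds shown here, putting trifluoromethoxy in place of trifluoromethyl on an aromatic carbon gives a 1.2-fold higher number from compound 2 to compound 4 (0.09 log units; within the scatter), a direct test of the added oxygen that the earlier compounds could not offer. Putting 3-(trifluoromethoxy)phenyl in place of 2-(trifluoromethyl)phenyl on a sulfonyl sulfur gives a 1.3-fold higher number from compound 3 to compound 4 (0.11 log units; within the scatter), so this change also produces no shift that can be told apart from ordinary repeat-to-repeat variation. No measurement at hand offers an explanation for this flat result.

From the compounds shown here alone, all three compounds with a number carry a fluorine-containing group on the aromatic ring attached to the sulfonyl sulfur, so it remains open whether an amine or a carboxylic acid on that ring would move the number beyond the scatter. Going by these compounds, compound 1, which carries a nitrile on the amide side of the molecule, gives no number, and it differs from the others in more than one place, so the effect of that nitrile also remains open.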